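Removing a methyl from compound 2: what to expect

The compounds below may be only part of what the source reports. "The series", "measured", "known", "first", "only" and "open" are said of these compounds alone.

compound 1, `COC(=O)c1c(C)cc(Oc2cc(C)cc(O)c2)cc1O`: 5940 nM
compound 2, `COc1cc(C)cc(Oc2cc(C)cc(O)c2)c1`: > 10000 nM

In a functional assay on K562 cells (Homo sapiens) for inhibition, read by MTT assay (on this read-out lower numbers stand for stronger inhibition and higher numbers for weaker inhibition), compound 1 gives 5940 nM. Compound 2 reaches only a limit of this assay, > 10000 nM. Compound 2 therefore stands at the limit of > 10000 nM in this assay, at which 1 of the 2 values shown sits, and no number for it is known. Compound 3, `Cc1cc(O)cc(Oc2cc(C)cc(O)c2)c1`, is not yet measured; it differs from compound 2 by hydrogen in place of methyl on an oxygen on an aromatic ring. Going by the values given here, no measured step of this kind exists here, so the size of the step in this assay is uncertain; a modest move towards stronger inhibition is expected, because compound 1, which also carries hydroxy groups, gives 5940 nM. The expected step is an at least 1.2-fold lower number from compound 2 to compound 3 (0.09 log units; that floor lies within the scatter). Compound 3 is estimated at 8000 nM, ranging from 3000 nM to 20000 nM.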

Compound 3, half-maximal inhibitory concentration: > 10000 nM
Compound 3 ended at the assay's limit; the forecaster's own chance of this, stated with the estimate: 40%; middle value at least 1.2-fold (0.09 log units) from the limit.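

In this assay compound 3 gives > 10000 nM, which is a limit and not a number. Going from methoxy to hydroxy therefore brings no value inside the range of the assay, and the step between compound 2 and compound 3 cannot be read, as both compounds now stand at the same limit: the limit of > 10000 nM in this assay, at which 2 of the 3 values shown sit.

Hydrogen in place of methoxycarbonyl on an aromatic carbon gives an at least 1.6-fold higher number from compound 1 to compound 3 (0.22 log units; that floor lies within the scatter), so the part played by the methoxycarbonyl remains unsettled. Still open, on these data alone, is whether a carboxylic acid in its place, or a longer chain on the oxygen, would give a number inside the range of this assay.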